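Azetidine nitrogen substituent in the pancreatic cell assay

This account rests on a few compounds, and the source may have more. Where it says the series, first, only, none or still open, it means among the compounds named here.

Measured so far:
compound 1 `CCN(CC)S(=O)(=O)c1ccc(S(=O)(=O)N2CCC[C@@H](C(=O)N(C)C(C)C)C2)cc1` gives 1400 nM in a functional assay on MIA PaCa-2 cells (Homo sapiens) for inhibition, read by MTT assay, with a stated time of 3 days; a higher number here means a weaker inhibitor, a lower number a stronger inhibitor.
compound 2 `CCN(CC)S(=O)(=O)c1ccc(S(=O)(=O)N2CCC[C@@H](C(=O)NC3CN(C(=O)C4CC4)C3)C2)cc1` gives 3100 nM in this assay.
compound 3 `CCN1CC(NC(=O)[C@@H]2CCCN(S(=O)(=O)c3ccc(S(=O)(=O)N(CC)CC)cc3)C2)C1` gives only a limit, > 10000 nM, in this assay.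

Compound 3 thus stands at the bottom of the shown numbers, beyond the reach of this assay; it is the one value sitting at the limit of > 10000 nM in this assay, at which 1 of the 3 values shown sits. The step to compound 4 `CCN(CC)S(=O)(=O)c1ccc(S(=O)(=O)N2CCC[C@@H](C(=O)NC3CN(C(=O)OC(C)(C)C)C3)C2)cc1` is tert-butoxycarbonyl in place of ethyl on an amine nitrogen in a ring.

The measured step that bears on this change is the reverse-direction one on the same ring nitrogen: an at least 3.2-fold higher number from compound 2 to compound 3 (0.50 log units; beyond the scatter). A carbonyl-bearing group on the azetidine nitrogen therefore gave a number within the assay window, while the ethyl group did not. The tert-butoxycarbonyl group likewise carries a carbonyl, so a drop from the limit of compound 3 into the measurable range is expected, of the order of an at least 2.8-fold lower number from compound 3 to compound 4 (0.45 log units; beyond the scatter). Compound 4 is accordingly estimated at 3500 nM, with a range from 1200 nM to 10000 nM. The upper end of that range allows for compound 4 remaining at the limit, since only one carbonyl-bearing substituent on this nitrogen, in compound 2, has been measured.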

Compound 4, half-maximal inhibitory concentration: 100 nM
Compound 4: middle estimate off by 35-fold (1.54 log units), on the high side; the whole stated range lies above it.
By their numbers in this assay, from the lowest: compound 4; then compound 1; then compound 2. At a limit, above all of these: compound 3.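

In this assay, tert-butoxycarbonyl in place of ethyl on the amine nitrogen of the azetidine gives an at least 100-fold lower number from compound 3 to compound 4 (2.00 log units; beyond the scatter), so this position can carry a large shift in the number. That step is only a bound, as the value of compound 3 is a limit: the limit of > 10000 nM in this assay, at which 1 of the 4 values shown sits. A carbonyl on this nitrogen does not settle the outcome by itself, since tert-butoxy in place of cyclopropyl on that carbonyl carbon gives a 31-fold lower number from compound 2 to compound 4 (1.49 log units; beyond the scatter); the azetidine amide bearing tert-butoxycarbonyl also reads lower than the isopropyl(methyl)amino amide, with a 14-fold lower number from compound 1 to compound 4 (1.15 log units; beyond the scatter), whereas the azetidine amides bearing cyclopropylcarbonyl and ethyl both read higher than that amide.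

From the compounds shown here alone, whether the lower number follows the oxygen joined to the carbonyl or the branched tert-butyl group stays open, and methoxycarbonyl and pivaloyl on this nitrogen would separate the two. The compounds shown also leave open how the free ring amine, with only a hydrogen on this nitrogen, would read in this assay.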